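A few compounds are considered here, and "the series" means these few. Any claim that something is new, unique, unknown or untested is made for them only; others in the source may bear on it.

Measured in a functional assay on HT-29 cells (Homo sapiens) for antiproliferative activity, read by MTT assay, with a stated time of 24 h; a lower number here means a stronger inhibitor, a higher number a weaker inhibitor:
Compound 1 `COc1ccc(/C=C/C(=O)c2ccc(OC)c3c2OC(C)(C)C=C3)c(F)c1`: > 10000 nM, a limit
Compound 2 `COc1ccc(C(=O)/C=C/c2ccc(F)cc2)c2c1C=CC(C)(C)O2`: > 10000 nM, a limit
Compound 3 `COc1ccc(C(=O)/C=C/c2cccc([N+](=O)[O-])c2)c2c1C=CC(C)(C)O2`: 4260 nM

Compound 3 is the only one of the three with a true number in this assay, while the other two sit at the limit of > 10000 nM in this assay, at which 2 of the 3 values shown sit. The unmeasured compound 4 `COc1ccc(C(=O)/C=C/c2ccco2)c2c1C=CC(C)(C)O2` has furan-2-yl in place of 3-nitrophenyl on a double-bonded chain carbon bound to a double-bonded chain carbon.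

Two measured steps at this same place bear on the change: an at least 2.3-fold lower number from compound 1 to compound 3 (0.37 log units; beyond the scatter) and an at least 2.3-fold lower number from compound 2 to compound 3 (0.37 log units; beyond the scatter). Both are beyond the scatter, and both end at the 3-nitrophenyl group. The step that the two limits leave unreadable from compound 1 to compound 2 cannot be read. For the measured compounds named here, no measured compound carries furan-2-yl, so the guide is indirect. Read in reverse, an at least 2.3-fold lower number from compound 2 to compound 3 (0.37 log units; beyond the scatter) leads to the expectation of a higher number once 3-nitrophenyl leaves, and a report of only a limit is quite possible. The expected step is a 2.1-fold higher number from compound 3 to compound 4 (0.32 log units; beyond the scatter). The estimated value for compound 4 is 9000 nM, with an expected range from 3000 nM to 30000 nM.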

Compound 4, half-maximal inhibitory concentration: > 10000 nM
Compound 4: a limit, no number; the forecaster's own chance of this, stated with the estimate: 50%; middle value at least 1.1-fold (0.04 log units) away from the limit.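

Putting furan-2-yl on a double-bonded chain carbon bound to a double-bonded chain carbon gives an at least 2.3-fold higher number from compound 3 to compound 4 (0.37 log units; beyond the scatter) in this assay, so a five-membered aromatic ring with a hetero atom does not keep the activity seen with 3-nitrophenyl. Of the four groups shown at this place, only 3-nitrophenyl gives a true number, and compound 3 stands alone against the limit reached by all the others: the limit of > 10000 nM in this assay, at which 3 of the 4 values shown sit. The steps from compound 1 and from compound 2 to compound 4 cannot be read.

It remains open whether the nitro group itself matters, since no compound shown has an amine or a carboxylic acid in its place on the phenyl ring. The limits also leave open how compound 1, compound 2 and compound 4 rank among themselves.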